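Thiophene Attachment Point and Adenosine A2b Binding

The compounds below may be only part of what the source reports. "The series", "measured", "known", "first", "only" and "open" are said of these compounds alone.

Measured compounds:
compound 1 `CC1=C(C(=O)CC(C)C)C(c2ccsc2)NC(=O)N1` — 1000 nM
compound 2 `CC1=C(C(=O)OCC2CC2)C(c2ccoc2)NC(=O)N1` — 426 nM
compound 3 `CC1=C(C(=O)OCC2CC2)C(c2cccs2)NC(=O)N1` — 1570 nM

Of the three compounds measured in an assay on membranes from HEK293 cells for displacement of a labelled ligand from adenosine receptor A2b (Homo sapiens), read by scintillation counting, with a stated time of 30 min (a higher number here means a weaker inhibitor, a lower number a stronger inhibitor), compound 3 gives the highest number, at 1570 nM. Within the data shown here, its nearest neighbour is compound 1, whose value lies within the scatter of it; compound 2 sits furthest away, and the only step that connects two measured compounds is a 3.7-fold higher number from compound 2 to compound 3 (0.57 log units; beyond the scatter).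

Compound 4 `CC1=C(C(=O)OCC2CC2)C(c2ccsc2)NC(=O)N1` is obtained from compound 3 by the change (thiophen-3-yl in place of thiophen-2-yl on a saturated ring carbon). Among the measured compounds shown here, no measured pair isolates exactly this change. The step from compound 2 to compound 3 is the only one that touches the five-membered ring at that position, and it shows that exchanging a furan-3-yl for a thiophen-2-yl there gave a modestly higher number. Compound 1 also carries a thiophen-3-yl, but differs from compound 4 in its seven-heavy-atom side group as well, so its value can only be read as loose context.

Taking the ring-position step as the best guide, compound 4 is expected to give a somewhat lower number than compound 3, about a 2.2-fold lower number from compound 3 to compound 4 (0.35 log units; beyond the scatter). The estimate for compound 4 is 700 nM, with a range from 300 nM to 1800 nM.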

Compound 4, inhibition constant: 724 nM
Compound 4: the middle estimate sits 1.0-fold (0.01 log units) below what was measured, and the stated range covers the measured number.
By their numbers in this assay, from the lowest: compounds 2, 4, 1 and 3 (each within the scatter of the next, the first and the last beyond it).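

In this assay, among these compounds, the attachment point of the thiophene on the saturated ring carbon counts on its own: with the same atoms joined differently, thiophen-3-yl in place of thiophen-2-yl gives a 2.2-fold lower number from compound 3 to compound 4 (0.34 log units; beyond the scatter) and so isolates a change that the earlier compounds only touched. With the attachment kept at the 3-yl position, thiophen-3-yl in place of furan-3-yl gives a 1.7-fold higher number from compound 2 to compound 4 (0.23 log units; within the scatter) and stays within the scatter, so among these compounds the earlier rise of a 3.7-fold higher number from compound 2 to compound 3 (0.57 log units; beyond the scatter) goes with the thiophen-2-yl attachment rather than with thiophene in place of furan as such. Cyclopropylmethoxy in place of isobutyl on the carbonyl carbon gives a 1.4-fold lower number from compound 1 to compound 4 (0.14 log units; within the scatter), also within the scatter, while nothing available accounts for the difference between the two thiophene attachments.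

The compounds shown leave open whether the gap between the two thiophene attachments also appears with the isobutyl group on the carbonyl carbon, and whether furan-2-yl departs from furan-3-yl in the same direction. They also do not tell how a phenyl group, or a methyl group or an amine added to the thiophene, would read at this position.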